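The source may hold more compounds than are shown below. What is called first, only, known or untested is meant among the compounds shown, and "the series" means these compounds.

In an ADME assay on the whole organism for metabolic stability, with Rattus norvegicus as the target (a higher number here means that the compound lasts longer, a lower number that the compound disappears faster), compound 1 `CCS(=O)(=O)n1cc2c(n1)CN([C@H]1CO[C@H](c3cc(F)ccc3F)[C@@H](N)C1)C2` gives 5.2 h and compound 2 `N[C@H]1C[C@@H](N2Cc3cnn(S(=O)(=O)C4CCCC4)c3C2)CO[C@@H]1c1cc(F)ccc1F` gives 0.5 h, while compound 3 `CCC(=O)Nc1n[nH]c2c1CN([C@H]1CO[C@H](c3cc(F)ccc3F)[C@@H](N)C1)C2` gives 2.2 h and so holds the middle place, lower than compound 1 and higher than compound 2 by gaps beyond the scatter. Compound 4 `CS(=O)(=O)Nc1n[nH]c2c1CN([C@H]1CO[C@H](c3cc(F)ccc3F)[C@@H](N)C1)C2` carries methylsulfonyl in place of propanoyl on a nitrogen on an aromatic ring and has not yet been measured. Among the compounds with values here, no measured pair isolates this change. Compound 1 at 5.2 h and compound 2 at 0.5 h both carry a sulfonyl group yet lie far apart, which gives no clear direction. In this assay only a small upward step within the scatter is expected a 1.4-fold higher number from compound 3 to compound 4 (0.13 log units; within the scatter) for this change. For compound 4 the estimated half-life is 3 h with a range from 1.2 h to 7 h for the coming measurement.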

Compound 4, half-life: 2 h
Beside the measured number, compound 4's estimate is 1.5-fold (0.18 log units) above it; the measured number falls inside the stated range.
By their numbers in this assay, from the lowest: compound 2; then compounds 4 and 3 (each within the scatter of the next); then compound 1.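

In this assay the pair that isolates this change shows a 1.1-fold lower number from compound 3 to compound 4 (0.04 log units; within the scatter) and so gives no sign that methylsulfonyl and propanoyl on a nitrogen on an aromatic ring differ in half-life. Within the data shown here, the sulfonyl group seen in the earlier compounds gave no direction, whereas at this position the exchange leaves the read-out within the scatter. No measured information is available to explain this result. The compounds shown leave open whether an amine or a longer acyl chain on this nitrogen would move the half-life beyond the scatter.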